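Swapping a propanoyl ester for a free alcohol on two cores

This account rests on a few compounds, and the source may have more. Where it says the series, first, only, none or still open, it means among the compounds named here.

Compound 1, `CCC(=O)NS(=O)(=O)c1ccc(-n2nc(C(F)F)cc2-c2ccc(Br)cc2)cc1COC(=O)CC`: 7.9 mg/kg
Compound 2, `CCC(=O)NS(=O)(=O)c1ccc(-n2nc(C(F)F)cc2-c2ccc(Br)cc2)cc1CO`: 5.6 mg/kg
Compound 3, `CCC(=O)NS(=O)(=O)c1ccc(-n2nc(C(F)(F)F)cc2-c2ccc3c(c2)CCC3)cc1COC(=O)CC`: 64 mg/kg

All three were tested in a functional assay on the whole organism (strain Wistar) with Rattus norvegicus as the target, read by paw edema; a higher number here means that more compound is needed for the effect, a lower number that less compound is needed. Compound 1 and compound 2 share one core, and the step of a 1.4-fold lower number from compound 1 to compound 2 (0.15 log units; within the scatter) comes from the change (hydrogen in place of propanoyl on an oxygen on a saturated carbon). Compound 3 is built on another core; the difference between the two cores is not broken down here, but in this assay compound 3 gives a number far higher than compound 1 or compound 2.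

Compound 4, `CCC(=O)NS(=O)(=O)c1ccc(-n2nc(C(F)(F)F)cc2-c2ccc3c(c2)CCC3)cc1CO`, has not been measured. For the measured compounds named here, it arises from compound 3 by hydrogen in place of propanoyl on an oxygen on a saturated carbon, the same change, at the same place, as the one between compound 1 and compound 2.

Because a 1.4-fold lower number from compound 1 to compound 2 (0.15 log units; within the scatter) lies within the scatter, a similarly small step is expected, estimated as a 1.4-fold lower number from compound 3 to compound 4 (0.15 log units; within the scatter). Compound 4 is therefore estimated at 45 mg/kg, expected between 20 mg/kg and 130 mg/kg.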

Compound 4, dose for half-maximal effect: 52 mg/kg
For compound 4 the middle estimate is 1.2-fold (0.06 log units) below the measured one, and the stated range covers the measured number.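

Replacing propanoyl with hydrogen on this oxygen again gives only a small change in this assay, with a 1.2-fold lower number from compound 3 to compound 4 (0.09 log units; within the scatter). The change carries over from one core to the other with much the same result: the same change on two cores in this assay, a 1.4-fold lower number (0.15 log units; within the scatter) from compound 1 to compound 2 and a 1.2-fold lower number (0.09 log units; within the scatter) from compound 3 to compound 4, 1.1-fold (0.06 log units) apart, within the scatter of two such steps. This shows that the propanoyl ester and the free alcohol cannot be told apart on these two cores in this assay, but it does not explain why, and two pairs do not make a rule for the whole series.

The compounds shown leave open what other groups on this oxygen would give, such as a longer chain than propanoyl or a simple methyl. Going by these compounds, an amine in place of the hydroxy also remains untested here, as does the same swap on a third core.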